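From trifluoromethyl to methyl on compound 1

The source may hold more compounds than are shown below. What is called first, only, known or untested is meant among the compounds shown, and "the series" means these compounds.

Values measured so far in a functional assay on HCT-15 cells (Homo sapiens) for inhibition, read by sulforhodamine B assay, with a stated time of 48 h, tested at 50 uM (a lower number here means less inhibition of growth, a higher number more inhibition of growth at the concentration tested), for two compounds
compound 1 `O=C(c1ccc(C(F)(F)F)c(F)c1)c1ccc2nc(NC(=O)C(F)(F)F)cn2c1` gives 59.2%
compound 2 `O=C(c1ccc2nc(NC(=O)C(F)(F)F)cn2c1)c1ccc(C(F)(F)F)cc1F` gives 100%

In this assay compound 1 holds the lower of the two numbers, and its gap to compound 2 lies beyond the usual scatter. Compound 3 `Cc1ccc(C(=O)c2ccc3nc(NC(=O)C(F)(F)F)cn3c2)cc1F` has not yet been tested. It carries methyl in place of trifluoromethyl on an aromatic carbon at the place ortho to a fluoro group and para to a large group. Among the compounds with values here, no measured pair shows this change, so the expectation rests on compound 1 at 59.2% alone and no firm direction can be argued. A small downward step, within the scatter, is expected. Compound 2 at 100% shows how far apart values can lie in this small set, so the range is kept wide. The estimated change is a number 4.2 percentage points lower from compound 1 to compound 3 (within the scatter) on this reasoning. For compound 3 the expected value is 55% with 25% to 90% as the estimated range.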

Compound 3, percent growth inhibition at one concentration: 65.5%
The estimate for compound 3 lay 10.5 percentage points below the measured number, and the stated range covers the measured number.
By their numbers in this assay, from the lowest: compounds 1 and 3 (each within the scatter of the next); then compound 2.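

In this assay, putting methyl in place of trifluoromethyl on an aromatic carbon, at the place ortho to a fluoro group and para to a large group, gives a number 6.3 percentage points higher from compound 1 to compound 3 (within the scatter). Within the data shown here, this is the first measured pair for this exchange, and it shows that, on the core of compound 1, the two groups cannot be told apart at this place by growth inhibition at the concentration tested, so trifluoromethyl is not required there for the level of inhibition seen. Nothing available bears on why the two groups read alike.

The compounds shown leave open whether an amine, a carboxylic acid or a longer chain at this place would read the same way. They also leave open whether the same exchange would give a similar step without the fluoro group.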